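The source may hold more compounds than are shown below. What is called first, only, known or untested is meant among the compounds shown, and "the series" means these compounds.

Measured values in an ADME assay on microsomes from liver (Homo sapiens) for metabolic stability, read by LC-MS, using NADPH, with stated times of 5 min and 30 min, tested at 1 uM (a higher number here means faster removal of the compound, a lower number slower removal), are as follows:

- compound 1 (`O=C(Nc1ccccc1)c1cnc(NCc2c(F)ccc3c2CCO3)n2cnnc12`): 14 mL.min-1.g-1
- compound 2 (`Cn1cc(-c2cnc(NCc3c(F)ccc4c3CCO4)c3cn[nH]c(=O)c23)cn1`): 21 mL.min-1.g-1

Among the compounds with values here, these two values lie within the usual scatter of each other, so compound 1 stands level with the only other compound measured so far. Compound 3 (`CN(c1ncco1)c1cnc(NCc2c(F)ccc3c2CCO3)n2cnnc12`) has yet to be measured. It carries methyl(1,3-oxazol-2-yl)amino in place of phenylcarbamoyl on an aromatic carbon of the core of compound 1 (methyl(1,3-oxazol-2-yl)amino in place of phenylcarbamoyl on an aromatic carbon). Within the data shown here, no measured pair in this small set isolates a single structural change, so nothing shows directly what this exchange does. Among the measured compounds shown here, with compound 1 at 14 mL.min-1.g-1 and compound 2 at 21 mL.min-1.g-1 as the only guides, a small rise is expected, one that stays inside the scatter. In this assay the estimated move is a 1.4-fold higher number from compound 1 to compound 3 (0.15 log units; within the scatter) and no larger shift is foreseen. For the measured compounds named here, the data offer no closer precedent for the entering group, so the range is kept wide. The expected value for compound 3 is 20 mL.min-1.g-1 within an estimated range of 9 mL.min-1.g-1 to 45 mL.min-1.g-1 in this measurement.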

Compound 3, intrinsic clearance in microsomes: 11 mL.min-1.g-1
Beside the measured number, compound 3's estimate is 1.8-fold (0.26 log units) above it; measured number inside the range.
By their numbers in this assay, from the lowest: compounds 3, 1 and 2 (each within the scatter of the next).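

In this assay, replacing phenylcarbamoyl with methyl(1,3-oxazol-2-yl)amino on this aromatic carbon gives a 1.3-fold lower number from compound 1 to compound 3 (0.10 log units; within the scatter), a step that lies within the scatter. Within the data shown here, this is the first pair in the set to differ in one place, and it shows that this position accepts a considerable exchange with no reading beyond the scatter: a six-membered aromatic ring of carbon only gives way to a five-membered aromatic ring with 2 hetero atoms, and the amide hydrogen is gone. Nothing in the data speaks to why the reading holds in this exchange.

The compounds shown leave open how an amine, a carboxylic acid or a longer chain on this aromatic carbon would read in this assay. Going by these compounds, they also do not separate the parts of the entering group, so the share of the oxazole ring, of the methyl and of the linking nitrogen remains unknown, as does whether the same exchange would give a similar step on a different core.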